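Bromo for chloro in a cytotoxicity series

The compounds below may be only part of what the source reports. "The series", "measured", "known", "first", "only" and "open" are said of these compounds alone.

Compound 3 `Clc1ccc(Cc2nn3c(Br)c(-c4ccc(Cl)cc4)nc3s2)cc1` carries a 4-chlorophenyl group. In an ADME assay on CCRF-CEM cells (Homo sapiens) for cytotoxicity, with a stated time of 72 h (on this read-out lower numbers stand for stronger inhibition and higher numbers for weaker inhibition), compound 3 gives only the limit > 250000 nM. Compound 1 `Clc1ccc(Cc2nn3cc(-c4ccc(Br)cc4)nc3s2)cc1` likewise gives only the limit > 250000 nM in this assay. Compound 2 `Fc1ccc(-c2nc3sc(Cc4ccc(Cl)cc4)nn3c2Br)cc1` also gives only the limit > 250000 nM in this assay. Going by the values given here, the one step between measured compounds, a step that the two limits leave unreadable from compound 2 to compound 3, cannot be sized because both ends sit at the limit of > 250000 nM in this assay, at which 3 of the 3 values shown sit. Compound 4 `Clc1ccc(Cc2nn3c(Br)c(-c4ccc(Br)cc4)nc3s2)cc1` differs from compound 3 by bromo in place of chloro on an aromatic carbon. Among the compounds with values here, no measured step carries a readable size for this change. Compound 4 is therefore expected to give no number beyond the limit as well, with an estimated step of a number no higher from compound 3 to compound 4 (the limit leaves the size open) of no readable size. For compound 4 an estimate of 250000 nM is given, expected to range from 100000 nM to 600000 nM.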

Compound 4, half-maximal inhibitory concentration: 238000 nM
Beside the measured number, compound 4's estimate is 1.1-fold (0.02 log units) above it; the range from low to high includes it.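

Going by these compounds alone, compound 4 is the first compound in this assay to give a number instead of a limit, yet the change from 4-chlorophenyl to 4-bromophenyl supports only an at least 1.0-fold lower number from compound 3 to compound 4 (0.02 log units; that floor lies within the scatter). The other two comparisons are no firmer, with an at least 1.0-fold lower number from compound 2 to compound 4 (0.02 log units; that floor lies within the scatter) and an at least 1.0-fold lower number from compound 1 to compound 4 (0.02 log units; that floor lies within the scatter), so none of these changes shows a clear gain. The series stays at the edge of the read-out: the limit of > 250000 nM in this assay, at which 3 of the 4 values shown sit.

As far as these compounds go, it remains open whether an amine or a carboxylic acid in place of the bromo on the 4-bromophenyl group would give a clearly lower number.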